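This account rests on a few compounds, and the source may have more. Where it says the series, first, only, none or still open, it means among the compounds named here.

Measured so far in a functional assay on SNB-75 cells (Homo sapiens) for inhibition, read by sulforhodamine B assay, with a stated time of 48 h; on this read-out lower numbers stand for higher toxicity in this test and higher numbers for lower toxicity in this test:
compound 1 `COc1cc2cc(Oc3ccc(NC(=O)Nc4cccc(C(F)(F)F)c4)cc3)c(C)nc2cc1OC` — > 50000 nM
compound 2 `COc1cc2cc(Oc3ccc(NC(=O)Nc4ccc(Cl)c(C(F)(F)F)c4)cc3)c(C)nc2cc1OC` — > 32500 nM

Compound 2 stands at a limit of this assay: its value > 32500 nM is a limit and not a number. Compound 1 likewise shows only a limit, > 50000 nM. Within the data shown here, the step that the two limits leave unreadable from compound 1 to compound 2 is therefore not readable, and it is the only measured step; none bears on the change to compound 3 `COc1cc2cc(Oc3ccc(NC(=O)Nc4ccc(Cl)c(Cl)c4)cc3)c(C)nc2cc1OC`, which is chloro in place of trifluoromethyl on an aromatic carbon. With no readable step to lean on, compound 3 is expected to remain at the limit as well, estimated at 50000 nM within 20000 nM to 100000 nM. The expected step is a step that the limit leaves unreadable from compound 2 to compound 3, none beyond the scatter.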

Compound 3, concentration lethal to 50% of the cells: 66100 nM
Beside the measured number, compound 3's estimate is 1.3-fold (0.12 log units) below it, and the stated range covers the measured number.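

No new step can be read in this assay: compound 3 can be set only against compound 1 and compound 2, and both of those show limits, not numbers. As far as these compounds go, the size of the effect of chloro in place of trifluoromethyl on an aromatic carbon in this assay stays open.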